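The source may report more compounds than this note shows. Statements on the series, on what has been measured and on what is new or still open speak of the compounds shown alone.

In an assay on membranes from CHO cells for displacement of a labelled ligand from adenosine receptor A1 (Homo sapiens), read by scintillation counting, with a stated time of 60 min, tested at 1 uM (on this read-out lower numbers stand for less inhibition and higher numbers for more inhibition at the one concentration tested (going by the name of the read-out)), compound 3 `CC1=C(C(=O)OCC(C)C)C(c2ccsc2)NC(=O)N1C` gives 8%, the second highest of the three numbers. Compound 2 `CCCOC(=O)C1=C(C)N(C)C(=O)NC1c1ccsc1` gives 2%, and compound 1 `CC1=C(C(=O)OC(C)(C)C)C(c2cccs2)NC(=O)N1C` gives 18%; both lie within the scatter of compound 3. Among the measured compounds shown here, the one measured step in the same part of the molecule, a number 6 percentage points higher from compound 2 to compound 3 (within the scatter), is small. Compound 4 `CC1=C(C(=O)OC(C)(C)C)C(c2ccsc2)NC(=O)N1C` differs from compound 3 in one place: tert-butyl in place of isobutyl on an oxygen next to a carbonyl group. For the measured compounds named here, no measured step bears directly on this swap; compound 1 carries the same tert-butyl group but differs from compound 3 in two places, so its value only hints that such a group keeps the number in the same low range. Compound 4 is therefore expected to give 12% (range 2% to 24%), and the step of a number 4 percentage points higher from compound 3 to compound 4 (within the scatter) is expected to stay within the scatter.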

Compound 4, a percentage reported as inhibition, at one concentration (the size of the read-out at that concentration, not a potency): 18%
For compound 4 the middle estimate is 6 percentage points below the measured one, and the stated range covers the measured number.
By their numbers in this assay, from the lowest: compounds 2, 3, 1 and 4 (each within the scatter of the next, the first and the last beyond it).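

With tert-butyl in place of isobutyl on an oxygen next to a carbonyl group, this assay shows a number 10 percentage points higher from compound 3 to compound 4 (within the scatter) and so does not separate these two groups. Tert-butyl in place of propyl at that oxygen gives a number 16 percentage points higher from compound 2 to compound 4 (beyond the scatter) as the first step here beyond the scatter, though a modest one. Thiophen-3-yl in place of thiophen-2-yl on a saturated ring carbon, a change no earlier step covered, gives no change at the digits printed from compound 1 to compound 4 (within the scatter) with tert-butyl present.

No supporting evidence accounts for these numbers. As far as these compounds go, whether a longer chain or an amine in place of tert-butyl would raise the number further remains open.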